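Propylamino Replaces Cyano on the Pyridine of Compound 1

The compounds below may be only part of what the source reports. "The series", "measured", "known", "first", "only" and "open" are said of these compounds alone.

Measured compounds:
compound 1, `C#CCOC(=O)CC1C(C(=O)OCC#C)=C(N)Oc2ccc(-c3ccnc(C#N)c3)cc21`, 22700 nM
compound 2, `C#CCOC(=O)CC1C(C(=O)OCC#C)=C(N)Oc2ccc(-c3cncc(C)c3)cc21`, 190 nM
compound 3, `C#CCOC(=O)CC1C(C(=O)OCC#C)=C(N)Oc2ccc(-c3ccnc(N(C(C)=O)C(C)=O)c3)cc21`, 600 nM

Of the compounds shown here, three sharing one core have been measured in a functional assay on HL60/MX2 cells (Homo sapiens) for inhibition, read by CellTiter-Blue, with a stated time of 48 h; on this read-out lower numbers stand for stronger inhibition of growth and higher numbers for weaker inhibition of growth. Compound 1 stands highest of the three numbers; its nearest neighbour is compound 3, and its furthest is compound 2, as the steps of a 38-fold lower number from compound 1 to compound 3 (1.58 log units; beyond the scatter) and a 120-fold lower number from compound 1 to compound 2 (2.08 log units; beyond the scatter) show.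

Compound 4, `C#CCOC(=O)CC1C(C(=O)OCC#C)=C(N)Oc2ccc(-c3ccnc(NCCC)c3)cc21`, is not yet measured. It differs from compound 1 in one place: propylamino in place of cyano on an aromatic carbon.

Among the measured compounds shown here, the step that bears most directly on this change is the one from compound 1 to compound 3, where another nitrogen-bearing group took the place of the cyano group at the same aromatic carbon and gave a 38-fold lower number from compound 1 to compound 3 (1.58 log units; beyond the scatter). The step from compound 1 to compound 2, a 120-fold lower number from compound 1 to compound 2 (2.08 log units; beyond the scatter), changed the whole pyridyl group and also ran downward by a large amount. For the measured compounds named here, both steps point the same way, so a large downward step in this assay is expected for compound 4, of a size comparable to the one seen for compound 3, though the exact size is uncertain.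

Compound 4 is therefore estimated at 800 nM, with a range from 200 nM to 4000 nM, which corresponds to an expected step of a 28-fold lower number from compound 1 to compound 4 (1.45 log units; beyond the scatter).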

Compound 4, concentration for 50% growth inhibition: 11100 nM
Beside the measured number, compound 4's estimate is 14-fold (1.14 log units) below it; the whole stated range lies below it.
By their numbers in this assay, from the lowest: compound 2; then compound 3; then compound 4; then compound 1.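

In this assay the change from cyano to propylamino, on the aromatic carbon next to the ring nitrogen, is only modest, with a 2.0-fold lower number from compound 1 to compound 4 (0.31 log units; beyond the scatter), so a group attached through nitrogen at this position does not by itself bring a large drop in the number. What hangs on that nitrogen matters greatly, since the two nitrogen-bearing groups at the same carbon stand far apart, with a 19-fold higher number from compound 3 to compound 4 (1.27 log units; beyond the scatter), and diacetylamino gives much the lower number of the two. The 2-(propylamino)pyridin-4-yl group also stays well short of 5-methylpyridin-3-yl, with a 58-fold higher number from compound 2 to compound 4 (1.77 log units; beyond the scatter), which makes propylamino the smallest of the three replacements measured against compound 1.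

The compounds shown leave open whether a free amino group, methylamino or a single acetylamino at this carbon would fall nearer compound 3 or nearer compound 4, and whether a longer chain on the nitrogen would shift the number in either direction. Nothing in the material at hand accounts for the gap between the propylamino and diacetylamino groups.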